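Adding Phenylsulfonyl to the Ring Nitrogen of Compound 2

The source may hold more compounds than are shown below. What is called first, only, known or untested is meant among the compounds shown, and "the series" means these compounds.

Compound 1 `CN1C/C(=C\c2cccnc2)C(=O)/C(=C/c2ccccc2F)C1` and compound 2 `O=C1/C(=C/c2cccnc2)CNC/C1=C\c1ccccc1F` share one core and differ only on an amine nitrogen in a ring. Among the compounds with values here, in an ADME assay on L02 cells (Homo sapiens) for cytotoxicity, read by MTT assay, with a stated time of 24 h (on this read-out lower numbers stand for stronger inhibition and higher numbers for weaker inhibition), compound 1 gives 15900 nM and compound 2 gives 15900 nM, so compound 2 stands level with its only measured neighbour. Within the data shown here, the single measured step, no change at the digits printed from compound 1 to compound 2 (within the scatter), replaces methyl with hydrogen at that nitrogen.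

Compound 3 `O=C1/C(=C/c2cccnc2)CN(S(=O)(=O)c2ccccc2)C/C1=C\c1ccccc1F` differs from compound 2 at the same place, with phenylsulfonyl in place of hydrogen on an amine nitrogen in a ring. Among the measured compounds shown here, the measured step is the only evidence bearing on this change, and it is a weak guide. For the measured compounds named here, it involves only methyl and hydrogen, and no measured compound carries phenylsulfonyl. Going by the values given here, with no change at the digits printed from compound 1 to compound 2 (within the scatter) as the sole precedent, no direction can be drawn, so no shift beyond the scatter is expected in this assay. The expected step is a 1.1-fold lower number from compound 2 to compound 3 (0.06 log units; within the scatter), and it remains quite uncertain. For compound 3 the estimate is 14000 nM, with an expected range from 5000 nM to 40000 nM.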

Compound 3, half-maximal inhibitory concentration: 15300 nM
Compound 3: the middle estimate sits 1.1-fold (0.04 log units) below what was measured; measured number inside the range.
By their numbers in this assay, from the lowest: compounds 3, 1 and 2 (each within the scatter of the next).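

Read in this assay the swap of hydrogen for phenylsulfonyl gives a 1.0-fold lower number from compound 2 to compound 3 (0.02 log units; within the scatter) while the swap of methyl for phenylsulfonyl gives a 1.0-fold lower number from compound 1 to compound 3 (0.02 log units; within the scatter) on the same nitrogen. The earlier compounds shown here had tested only hydrogen and methyl at this amine nitrogen in a ring, whereas phenylsulfonyl brings 9 heavy atoms and a six-membered aromatic ring of carbon only, and the three compounds still cannot be told apart on this read-out. Nothing available here explains why the numbers agree.

The compounds shown leave open whether a different group on this nitrogen, such as acetyl, benzyl or a chain ending in a carboxylic acid, would give a number beyond the scatter. From the compounds shown here alone, all of these results also come from a single cytotoxicity test on one cell type, so how the same changes would read in any other test remains unknown.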